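The compounds below may be only part of what the source reports. "The series", "measured", "known", "first", "only" and "open" are said of these compounds alone.

In a toxicity assay on L3.6pl cells (Homo sapiens) for inhibition, read by ATP content, with a stated time of 72 h (a higher number here means a weaker inhibitor, a lower number a stronger inhibitor), compound 1 `COc1ccccc1C(=O)Nc1ccc(N2CCN(c3cc(Cl)ccc3C)CC2)cc1C(=O)O` gives 29100 nM. Within the data shown here, this is the lower of the two numbers measured so far, as compound 2 `COc1ccc(C(=O)Nc2ccc(N3CCN(c4cc(Cl)ccc4C)CC3)cc2C(=O)O)c(OC)c1` gives 61600 nM. Compound 3 `COc1ccccc1C(=O)Nc1ccc(N2CCN(Cc3ccccc3)CC2)cc1C(=O)O` keeps the core of compound 1 but changes one group: benzyl in place of 5-chloro-2-methylphenyl on an amine nitrogen in a ring. Benzyl takes the place of 5-chloro-2-methylphenyl on an amine nitrogen in a ring. Among the measured compounds shown here, only one measured step is available as a guide, a 2.1-fold higher number from compound 1 to compound 2 (0.33 log units; beyond the scatter), which is modest and comes from methoxy in place of hydrogen on an aromatic carbon. That is a different change in a different place, so it gives only a rough idea of scale. In this assay, a similarly modest shift toward a higher number is therefore expected, though the direction is uncertain. The expected step is a 1.4-fold higher number from compound 1 to compound 3 (0.16 log units; within the scatter). The estimate for compound 3 is 42000 nM, with an expected range of 15000 nM to 110000 nM.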

Compound 3, half-maximal inhibitory concentration: > 10000 nM
Compound 3 was reported as a limit (the forecaster's own chance of this, stated with the estimate: 25%); the middle value does not contradict the limit.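

Compound 3 is reported only as a limit, so the step from compound 1 to compound 3 cannot be read: the limit of > 10000 nM in this assay, at which 1 of the 3 values shown sits. From the compounds shown here alone, what stays open is whether benzyl in place of 5-chloro-2-methylphenyl gives a higher, lower or similar number in this assay compared with compound 1.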